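Shortening the Chain of a Hydroxamic Acid Inhibitor

A few compounds are considered here, and "the series" means these few. Any claim that something is new, unique, unknown or untested is made for them only; others in the source may bear on it.

Of the compounds shown here, three have been measured in an assay on isolated protein for inhibition of histone deacetylase 8 (Homo sapiens), read by fluorescence; on this read-out higher numbers stand for weaker inhibition and lower numbers for stronger inhibition. Compound 1 `C#CCN(C)CCCOc1cc(NCc2ccc(/C=C/C(=O)NO)cc2)ccc1Cl` gives 80 nM, compound 3 `C#CCN(C)CCCOc1ccc(NC(=O)CCCCCCC(=O)NO)cc1Cl` gives 330 nM, and compound 2 `C#CCN(C)CCCOc1cc(NC(=O)CCCCCCCCC(=O)NO)ccc1Cl` gives 2480 nM. Compound 2 thus stands with the highest number of the three, that is, the weakest inhibition: its nearest neighbour is compound 3, and the gap to both compound 3 and compound 1 lies beyond the usual scatter of repeated measurements.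

The step now followed goes from compound 2 to compound 4 `C#CCN(C)CCCOc1cc(NC(=O)CCCCCCC(=O)NO)ccc1Cl`, which has not yet been measured. The change is hydroxycarbamoyl in place of 2-(hydroxycarbamoyl)ethyl on a saturated chain carbon, six bonds along the chain from a carbonyl carbon, in other words hydroxycarbamoyl in place of 2-(hydroxycarbamoyl)ethyl on a saturated chain carbon, six bonds along the chain from a carbonyl carbon. The linker between the amide and the hydroxamic acid thus becomes shorter while both ends stay the same.

Going by the values given here, no measured pair shows this exact step. Compound 4 carries a chain of the same length as compound 3, however, and compound 3 gives 330 nM, well below the value of compound 2. On that basis compound 4 is expected to show stronger inhibition than compound 2, a step of a 6.2-fold lower number from compound 2 to compound 4 (0.79 log units; beyond the scatter) that should exceed the scatter. The estimate for compound 4 is 400 nM, with a range from 150 nM to 1100 nM.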

Compound 4, half-maximal inhibitory concentration: 50 nM
Beside the measured number, compound 4's estimate is 8.0-fold (0.90 log units) above it; measured number outside the range, below it.
By their numbers in this assay, from the lowest: compounds 4 and 1 (each within the scatter of the next); then compound 3; then compound 2.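

In this assay the change to hydroxycarbamoyl from 2-(hydroxycarbamoyl)ethyl, on a saturated chain carbon six bonds along the chain from a carbonyl carbon, gives a 50-fold lower number from compound 2 to compound 4 (1.70 log units; beyond the scatter) and so counts as a large step towards stronger inhibition. Going by these compounds alone, compounds 2 and 4 form the only pair here that differ in one place, so this step isolates the effect of chain length: with the shared core and the hydroxamic acid end kept the same, the shorter chain alone goes with a far lower number. The compounds shown offer no measurement that explains why this shortening has so large an effect.

Going by these compounds, with only these two chain lengths on this core, it remains open whether the trend continues with a still shorter chain, or whether a chain of intermediate length falls between these two values. On these data alone, it is also open how much of the inhibition depends on the hydroxamic acid itself, which a carboxylic acid at the end of the same chain would test, and whether the step would be as large on a different core.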